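The source may hold more compounds than are shown below. What is called first, only, known or untested is meant among the compounds shown, and "the series" means these compounds.

Values in a physicochemical assay for solubility, in phosphate buffer, at pH 6.5; a lower number here means a less soluble compound, a higher number a more soluble compound

Compound 1 `C=C[C@@H]1C[C@]1(NC(=O)[C@@H]1C[C@@H](Oc2nccc3cc(OC)ccc23)CN1C(=O)[C@@H](NC(=O)N[C@H](COC)[C@@H](C)CC)C(C)(C)C)C(=O)NS(=O)(=O)C1CC1` gives 326 ug/mL
Compound 2 `C=C[C@@H]1C[C@]1(NC(=O)[C@@H]1C[C@@H](Oc2nccc3cc(OC)ccc23)CN1C(=O)[C@@H](NC(=O)N[C@H](COC)C(C)(C)C)C(C)(C)C)C(=O)NS(=O)(=O)C1CC1` gives 609 ug/mL
Compound 3 `C=C[C@@H]1C[C@]1(NC(=O)[C@@H]1C[C@@H](Oc2nccc3cc(OC)ccc23)CN1C(=O)[C@@H](NC(=O)N[C@H](C(=O)O)C(C)(C)C)C(C)(C)C)C(=O)NS(=O)(=O)C1CC1` gives > 1160 ug/mL, which is a limit and not a number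

So compound 3 stands on a limit, and its true number is not known. Compound 4 `C=C[C@@H]1C[C@]1(NC(=O)[C@@H]1C[C@@H](Oc2nccc3cc(OC)ccc23)CN1C(=O)[C@@H](NC(=O)N[C@H](C(=O)NCc1ccccc1)C(C)(C)C)C(C)(C)C)C(=O)NS(=O)(=O)C1CC1` differs from it at one place: benzylamino in place of hydroxy on a carbonyl carbon, which turns carboxy into benzylcarbamoyl.

For the measured compounds named here, two measured steps bear on this. Putting carboxy in place of methoxymethyl gave an at least 1.9-fold higher number from compound 2 to compound 3 (0.27 log units; that floor lies within the scatter), and the wider change gave an at least 3.5-fold higher number from compound 1 to compound 3 (0.55 log units; beyond the scatter). Compound 4 no longer carries that carboxy, so a return towards compound 2 at 609 ug/mL and compound 1 at 326 ug/mL seems likely. Going by the values given here, no measured step covers the incoming benzyl ring, so the range stays wide.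

The expected change is an at least 5.8-fold lower number from compound 3 to compound 4 (0.76 log units; beyond the scatter), a drop in this assay beyond the scatter. Compound 4 is estimated at 200 ug/mL (expected range 50 ug/mL to 600 ug/mL).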

Compound 4, solubility: 95 ug/mL
Beside the measured number, compound 4's estimate is 2.1-fold (0.32 log units) above it, and the stated range covers the measured number.
By their numbers in this assay, from the lowest: compound 4; then compounds 1 and 2 (each within the scatter of the next). At a limit, above all of these: compound 3.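

In this assay, turning carboxy into benzylcarbamoyl on this carbonyl carbon gives an at least 12-fold lower number from compound 3 to compound 4 (1.08 log units; beyond the scatter), so the earlier rise on reaching the carboxy now has a fall to set against it. Compound 3 rests on a limit and not a number, so the size of that step is only a floor: the limit of > 1160 ug/mL in this assay, at which 1 of the 4 values shown sits. The change also does not simply return to the level of the methoxymethyl side chain, since benzylcarbamoyl in place of methoxymethyl gives a 6.4-fold lower number from compound 2 to compound 4 (0.81 log units; beyond the scatter).

The compounds shown cannot separate the part played by the amide from the part played by the benzyl ring, as both enter together. A methyl amide or a plain primary amide on the same carbonyl carbon would show how much of the drop remains without that ring.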